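Working notes on nitrogen-linked group variation

The source may report more compounds than this note shows. Statements on the series, on what has been measured and on what is new or still open speak of the compounds shown alone.

Compound 3 `CCCCOC(=O)NS(=O)(=O)c1sc(CC(C)C)cc1-c1ccc(CN2C(=O)N(C)C(C)(C)C2=O)cc1` gives 3.6 nM in an assay on membranes from uterus for displacement of a labelled ligand from Angiotensin type II receptor (Sus scrofa), with a stated time of 1.5 h; on this read-out higher numbers stand for weaker inhibition and lower numbers for stronger inhibition. Among the three numbers so far it stands second highest: compound 2 `CCCCOC(=O)NS(=O)(=O)c1sc(CC(C)C)cc1-c1ccc(CN2CCCC2=O)cc1` gives 3.5 nM, and the step of a 1.0-fold higher number from compound 2 to compound 3 (0.01 log units; within the scatter) is within the scatter, whereas compound 1 `CCCCOC(=O)NS(=O)(=O)c1sc(CC(C)C)cc1-c1ccc(CN2CCN(C)C2=O)cc1` gives 16.5 nM, and a 4.6-fold lower number from compound 1 to compound 3 (0.66 log units; beyond the scatter) lies beyond it. Compound 4 `CCCCOC(=O)NS(=O)(=O)c1sc(CC(C)C)cc1-c1ccc(Cn2cnc(C(F)(F)F)c2)cc1` differs from compound 3 by 4-(trifluoromethyl)-1H-imidazol-1-yl in place of 3,4,4-trimethyl-2,5-dioxoimidazolidin-1-yl on a saturated chain carbon bound to an aromatic carbon. Going by the values given here, the steps that bear on this change are a 4.7-fold lower number from compound 1 to compound 2 (0.67 log units; beyond the scatter), a 4.6-fold lower number from compound 1 to compound 3 (0.66 log units; beyond the scatter) and a 1.0-fold higher number from compound 2 to compound 3 (0.01 log units; within the scatter), all swaps of a nitrogen-linked group at the same place; two were modest and one fell within the scatter. A shift of at most modest size in this assay is therefore expected, in either direction. Compound 4 is estimated at 5 nM, with a range from 1.5 nM to 20 nM. This amounts to an expected step of a 1.4-fold higher number from compound 3 to compound 4 (0.14 log units; within the scatter).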

Compound 4, inhibition constant: 7.3 nM
The estimate for compound 4 lay 1.5-fold (0.16 log units) below the measured number, within the range that was stated.
By their numbers in this assay, from the lowest: compounds 2 and 3 (each within the scatter of the next); then compound 4; then compound 1.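

In this assay, an aromatic ring at this place proves compatible with binding, but the outcome depends on the group it replaces: a 2.0-fold higher number from compound 3 to compound 4 (0.31 log units; beyond the scatter) and a 2.1-fold higher number from compound 2 to compound 4 (0.32 log units; beyond the scatter) are modest losses, whereas a 2.3-fold lower number from compound 1 to compound 4 (0.35 log units; beyond the scatter) is a modest gain. Compound 4 therefore falls inside the range set by the non-aromatic rings, with compound 1 going against any ranking of aromatic below non-aromatic. Nothing available explains these shifts.

The compounds shown do not separate the aromatic ring from its trifluoromethyl group. On these data alone, an unsubstituted imidazole, or one carrying a carboxylic acid instead, remains open.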